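A few compounds are considered here, and "the series" means these few. Any claim that something is new, unique, unknown or untested is made for them only; others in the source may bear on it.

Three compounds share one core and differ only in the group carried on an amide-type nitrogen. In an assay on isolated protein for inhibition of proto-oncogene tyrosine-protein kinase receptor Ret variant V804M (Homo sapiens), read by 33P incorporation, with stated times of 15 min and 40 min (on this read-out lower numbers stand for stronger inhibition and higher numbers for weaker inhibition), compound 1 `COc1cccc(NC(=O)Nc2ccc(Nc3ncnc4c3OCCN4)cc2)c1` gives 5290 nM. Compound 2 `Cc1ccc(F)c(NC(=O)Nc2ccc(Nc3ncnc4c3OCCN4)cc2)c1` gives 5110 nM, and compound 3 `O=C(Nc1ccc(Nc2ncnc3c2OCCN3)cc1)Nc1cccc(-c2ccccc2)c1` gives 7590 nM. Compound 1 stands second highest of the three, and both of its neighbours sit within the scatter: a 1.0-fold lower number from compound 1 to compound 2 (0.02 log units; within the scatter), and a 1.4-fold higher number from compound 1 to compound 3 (0.16 log units; within the scatter).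

Compound 4 `CC(C)(C)c1csc(NC(=O)Nc2ccc(Nc3ncnc4c3OCCN4)cc2)n1` differs from compound 1 by 4-(tert-butyl)-1,3-thiazol-2-yl in place of 3-methoxyphenyl on an amide-type nitrogen. The two measured steps each swapped one aromatic group at this same nitrogen and neither moved the number beyond the scatter, so no step beyond the scatter is expected here either, although a five-membered ring with two hetero atoms is a wider departure than either measured swap and leaves the range broad. The expected step is a 1.1-fold lower number from compound 1 to compound 4 (0.02 log units; within the scatter), giving compound 4 an estimated 5000 nM, between 1500 nM and 16000 nM.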

Compound 4, half-maximal inhibitory concentration: 5170 nM
Beside the measured number, compound 4's estimate is 1.0-fold (0.01 log units) below it, within the range that was stated.
By their numbers in this assay, from the lowest: compounds 2, 4, 1 and 3 (each within the scatter of the next).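

In this assay the change now reaches the aromatic ring itself, not only the groups on it: the five-membered 4-(tert-butyl)-1,3-thiazol-2-yl ring, which holds nitrogen and sulfur, gives a 1.0-fold lower number from compound 1 to compound 4 (0.01 log units; within the scatter) and a 1.0-fold higher number from compound 2 to compound 4 (0.01 log units; within the scatter). At this amide-type nitrogen, then, a six-membered ring of carbon only is not required to keep the number at this level among these compounds. Nothing measured here accounts for this absence of change. Still open, from the compounds shown here alone, is whether a group with no aromatic ring, such as a plain alkyl chain, an amine or a carboxylic acid, would shift the number on this nitrogen.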